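Piperidine nitrogen substituents: from compound 3 to compound 4

The source may hold more compounds than are shown below. What is called first, only, known or untested is meant among the compounds shown, and "the series" means these compounds.

Compound 3 `Cc1nnc(N2CCC(C(=O)N3N=CC[C@H]3c3ccccc3)CC2)o1` stands second highest of the three numbers in a physicochemical assay for lipophilicity, read by HPLC, measured as chromatographic lipophilicity, at pH 7.4 (a lower number here means a more polar compound, a higher number a more lipophilic compound), where compound 3 gives 3.2. Its nearest neighbour is compound 1 `O=C(c1cscn1)N1CCC(C(=O)N2N=CC[C@H]2c2ccccc2)CC1`, for which compound 1 gives 3; the step of a number 0.20 log units higher from compound 1 to compound 3 (within the scatter) is within the scatter. Its furthest is compound 2 `O=C(C1CCN(c2ccccn2)CC1)N1N=CC[C@H]1c1ccccc1`, for which compound 2 gives 5.1; the step of a number 1.90 log units lower from compound 2 to compound 3 (beyond the scatter) is large.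

Compound 4 `O=C(C1CCN(c2ncccn2)CC1)N1N=CC[C@H]1c1ccccc1` differs from compound 3 in one place: pyrimidin-2-yl in place of 5-methyl-1,3,4-oxadiazol-2-yl on an amine nitrogen in a ring.

The step that bears most directly on this is a number 1.90 log units lower from compound 2 to compound 3 (beyond the scatter), the same ring nitrogen carrying a six-membered aromatic ring in place of the five-membered one; a number 2.10 log units higher from compound 1 to compound 2 (beyond the scatter) points the same way. Among the compounds with values here, the six-membered ring that enters here carries two ring nitrogens rather than the one of compound 2, so the full reverse of the step from compound 2 to compound 3 is not expected, but a clear rise is.

Compound 4 is therefore expected at 4.2, within 3.6 to 4.8, an estimated step of a number 1.00 log units higher from compound 3 to compound 4 (beyond the scatter).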

Compound 4, distribution coefficient: 4.7
The estimate for compound 4 lay 0.50 log units below the measured number, within the range that was stated.
By their numbers in this assay, from the lowest: compounds 1 and 3 (each within the scatter of the next); then compound 4; then compound 2.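

In this assay, the exchange of the five-membered for the six-membered aromatic ring on the amine nitrogen in a ring now holds with two ring nitrogens as well as one: the step is a number 1.50 log units higher from compound 3 to compound 4 (beyond the scatter), and pyrimidin-2-yl also stands well apart from the (1,3-thiazol-4-yl)carbonyl group, with a number 1.70 log units higher from compound 1 to compound 4 (beyond the scatter). The position also separates two six-membered aromatic rings, pyrimidin-2-yl and pyridin-2-yl, though by a smaller margin, with a number 0.40 log units lower from compound 2 to compound 4 (beyond the scatter). Within these four compounds, the group on this nitrogen therefore spans a graded range of values rather than two clusters alone.

Where a carboxylic acid or a longer alkyl chain on this same nitrogen would fall in this assay remains open. Nothing given here accounts for the size of these steps.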